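A few compounds are considered here, and "the series" means these few. Any claim that something is new, unique, unknown or untested is made for them only; others in the source may bear on it.

Among the measured compounds shown here, compound 1 `CCc1ccc(C(=O)N2CCN(Cc3nc4ccccc4n3Cc3cccc(C)c3)CC2)cc1` is one of two compounds measured in an assay on isolated protein for inhibition of aldehyde dehydrogenase 1A1 (Homo sapiens), read by spectrophotometry, tested at 10 uM; a lower number here means less inhibition, a higher number more inhibition at the concentration tested (going by the name of the read-out); compound 1 gives 67%. For the measured compounds named here, compound 2 `Cc1ccc(C(=O)N2CCN(Cc3nc4ccccc4n3Cc3cccc(C)c3)CC2)cc1` gives 64.9% in this assay, and the only measured step, a number 2.1 percentage points lower from compound 1 to compound 2 (within the scatter), changes nothing beyond the scatter, so compound 2 stands level with compound 1. Compound 3 `CCCC(=O)N1CCN(Cc2nc3ccccc3n2Cc2cccc(C)c2)CC1` differs from compound 2 by propyl in place of 4-methylphenyl on a carbonyl carbon. Going by the values given here, no measured step touches a change of this kind, so the expectation rests on compound 2 alone, with wide uncertainty. Compound 3 is expected to show 50%, between 20% and 75%, an expected step of a number 14.9 percentage points lower from compound 2 to compound 3 (beyond the scatter) in this assay.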

Compound 3, a percentage reported as inhibition, at one concentration (the size of the read-out at that concentration, not a potency): 79.1%
Beside the measured number, compound 3's estimate is 29.1 percentage points below it, and the stated range ends below it.
By their numbers in this assay, from the lowest: compounds 2 and 1 (each within the scatter of the next); then compound 3.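

Swapping 4-methylphenyl for propyl on the carbonyl carbon raises inhibition in this assay (a number 14.2 percentage points higher from compound 2 to compound 3 (beyond the scatter)), and swapping 4-ethylphenyl for propyl does the same (a number 12.1 percentage points higher from compound 1 to compound 3 (beyond the scatter)). Among these compounds, then, an aromatic ring at this position is not needed for inhibition at the tested concentration, and this is the first change here to move the number beyond the scatter. Still open, going by these compounds, is whether a longer chain such as pentyl, or a chain ending in an amine or a carboxylic acid, would keep or extend this rise. No measurement at hand accounts for the rise.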